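Anilide series: methyl count and chromatographic lipophilicity

The source may hold more compounds than are shown below. What is called first, only, known or untested is meant among the compounds shown, and "the series" means these compounds.

Three anilides on a shared core have been run in a physicochemical assay for lipophilicity, read by HPLC, in phosphate buffer, measured as chromatographic lipophilicity, at pH 7.4; a lower number here means a more polar compound, a higher number a more lipophilic compound. Compound 1 `COc1ccc2nc(C)cc(OCC(=O)Nc3cc(C)cc(C)c3)c2c1` gives 5.64, compound 2 `COc1ccc2nc(C)cc(OCC(=O)Nc3ccccc3)c2c1` gives 4.28, and compound 3 `COc1ccc2nc(C)cc(OCC(=O)Nc3cccc(C)c3)c2c1` gives 4.83. Compound 3 stands second highest of the three, with compound 2 below it and compound 1 above it; the steps of a number 0.55 log units higher from compound 2 to compound 3 (beyond the scatter) and a number 0.81 log units lower from compound 1 to compound 3 (beyond the scatter) lie beyond the scatter, as does a number 1.36 log units lower from compound 1 to compound 2 (beyond the scatter).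

Compound 4 `COc1ccc2nc(C)cc(OCC(=O)Nc3cc(C)ccc3C)c2c1` has not been measured. From compound 3 it differs by methyl in place of hydrogen on an aromatic carbon, placed on an aromatic carbon of a six-membered aromatic ring of carbon only, ortho to a large group and para to a methyl group. The two steps that bear on this change each add or remove one methyl on that same ring: a number 0.55 log units higher from compound 2 to compound 3 (beyond the scatter) and, read in reverse, a number 0.81 log units lower from compound 1 to compound 3 (beyond the scatter). A step of comparable size upward in this assay is therefore expected for compound 4, estimated as a number 0.62 log units higher from compound 3 to compound 4 (beyond the scatter). For compound 4 the expected value is 5.45, with a range from 5.05 to 5.85.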

Compound 4, distribution coefficient: 5.05
Beside the measured number, compound 4's estimate is 0.40 log units above it; the range from low to high includes it.
By their numbers in this assay, from the lowest: compound 2; then compounds 3 and 4 (each within the scatter of the next); then compound 1.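

In this assay, for the compounds shown here, methyl in place of hydrogen at this carbon, ortho to a large group and para to a methyl group, gives a number 0.22 log units higher from compound 3 to compound 4 (within the scatter) and so adds no step that can be told apart from the scatter, whereas the earlier methyl step gave a number 0.55 log units higher from compound 2 to compound 3 (beyond the scatter) beyond it. The same count of methyl groups does not fix the number, since 2,5-dimethylphenyl in place of 3,5-dimethylphenyl gives a number 0.59 log units lower from compound 1 to compound 4 (beyond the scatter) while 2,5-dimethylphenyl in place of phenyl still gives a number 0.77 log units higher from compound 2 to compound 4 (beyond the scatter) on this scale. Nothing in hand gives a cause for this difference between the two dimethylphenyl groups.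

Open, on these data alone, is the reading for a methyl at this carbon without the other methyl on the ring. Also open, as far as these compounds go, is whether an amine or a carboxylic acid at this carbon would shift the number.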